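Swapping a hydroxy for bromo on a shared hydrazone core

This account rests on a few compounds, and the source may have more. Where it says the series, first, only, none or still open, it means among the compounds named here.

Compound 1 `Oc1ccc(/C=N/n2cnnc2)cc1O` gives 5690 nM in an assay for inhibition of Alpha amylase (Homo sapiens), with a stated time of 10 min (on this read-out higher numbers stand for weaker inhibition and lower numbers for stronger inhibition), the second highest of three numbers. Compound 2 `Oc1ccc(/C=N/n2cnnc2)c(O)c1O` gives 5920 nM, and the step of a 1.0-fold higher number from compound 1 to compound 2 (0.02 log units; within the scatter) shows that adding a hydroxy changed little. Compound 3 `Clc1ccc(/C=N/n2cnnc2)cc1` gives 4360 nM; its value and that of compound 1 lie within the scatter of one another. Compound 4 `Oc1ccc(/C=N/n2cnnc2)cc1Br` is not yet measured; it differs from compound 1 by bromo in place of hydroxy on an aromatic carbon. Among the measured compounds shown here, no measured step covers this exact change, and the only step, from compound 1 to compound 2, was within the scatter. Compound 4 is therefore expected to show a step of a 1.2-fold lower number from compound 1 to compound 4 (0.07 log units; within the scatter), essentially none beyond the scatter. Compound 4 is estimated at 4800 nM, between 2400 nM and 9600 nM.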

Compound 4, half-maximal inhibitory concentration: 2270 nM
Compound 4: the middle estimate sits 2.1-fold (0.33 log units) above what was measured; measured number below the stated range.
By their numbers in this assay, from the lowest: compounds 4, 3, 1 and 2 (each within the scatter of the next, the first and the last beyond it).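

Among the compounds shown, this is the first single change to move the number beyond the scatter in this assay: bromo in place of hydroxy gives a 2.5-fold lower number from compound 1 to compound 4 (0.40 log units; beyond the scatter). The hydroxy at this place on the ring is therefore not needed for inhibition, and the place responds to the group it carries. Nothing measured here explains why this swap gives a lower number.

Still open, from the compounds shown here alone, is how fluoro, methoxy or an amine would behave at this same place. Also open, going by these compounds, is whether the remaining hydroxy is needed alongside the bromo.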